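Compound 3 to compound 4: expected shift in cellular potency

The source may hold more compounds than are shown below. What is called first, only, known or untested is meant among the compounds shown, and "the series" means these compounds.

Of the compounds shown here, three have been measured in a functional assay on cells (T-cell, Homo sapiens) for inhibition; a higher number here means a weaker inhibitor, a lower number a stronger inhibitor. Compound 1 `CC(C)Oc1nc(N)nc2ncc(-c3ccc(F)c(F)c3)nc12` gives 10000 nM, compound 2 `CCOc1nc(N)nc2ncc(-c3ccc(CC)cc3)nc12` gives 8200 nM, and compound 3 `COc1ccc(-c2cnc3nc(N)nc(N4CCN(c5ccc(C)cc5)CC4)c3n2)cc1OC` gives 300 nM. Compound 3 stands lowest of the three numbers; its nearest neighbour is compound 2 and its furthest is compound 1, and both gaps lie beyond the scatter. Compound 3 differs from compounds 1 and 2 in more than one place, so no single structural step can be read off from these three.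

Compound 4 `COc1ccc(-c2cnc3nc(N)nc(N4CCN(C(=O)Nc5ccc(F)cc5)CC4)c3n2)cc1OC` is next to be measured in this assay. It differs from compound 3 in one place: (4-fluorophenyl)carbamoyl in place of 4-methylphenyl on an amine nitrogen in a ring. For the measured compounds named here, no pair of measured compounds differs only in this place, so the size of this step is not known from the data. Going by the values given here, compound 3 is the only measured compound bearing a large group on the amine nitrogen in a ring, and nothing shows what exchanging that group does. The step of a 2.0-fold higher number from compound 3 to compound 4 (0.30 log units; within the scatter) is expected to be small and toward a higher number, though a result within the scatter would not be surprising. Compound 4 is estimated at 600 nM, with a range from 150 nM to 2500 nM.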

Compound 4, half-maximal inhibitory concentration: 7 nM
Estimate against measurement, compound 4: 86-fold (1.93 log units) above, outside the stated range (below it).
By their numbers in this assay, from the lowest: compound 4; then compound 3; then compounds 2 and 1 (each within the scatter of the next).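

In this assay the group on the amine nitrogen in a ring proves decisive for this pair: (4-fluorophenyl)carbamoyl in place of 4-methylphenyl gives a 43-fold lower number from compound 3 to compound 4 (1.63 log units; beyond the scatter) with the rest of the molecule unchanged. The entering group carries a carbonyl and an amide hydrogen that the leaving group lacks, and it also carries a fluorine, so this one step cannot separate the contribution of the carbamoyl link from that of the fluorine. Nothing available accounts for the size of this step.

Open, as far as these compounds go, is whether the carbamoyl link alone carries the step, which an unsubstituted phenylcarbamoyl or a 4-methylphenylcarbamoyl on the same nitrogen would test. Equally open, from the compounds shown here alone, is whether a chlorine or a methoxy group in place of the fluorine keeps the number this low.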